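Aryl vinyl ketone series: ester and side-chain changes

This account rests on a few compounds, and the source may have more. Where it says the series, first, only, none or still open, it means among the compounds named here.

Compound 1 `COc1ccc(C(=O)/C(=C/c2c(F)c(F)c(F)c(F)c2F)CCOC(C)=O)cc1` gives 58100 nM in a functional assay on A549 cells (Homo sapiens) for inhibition, read by XTT assay, with a stated time of 48 h; a higher number here means a weaker inhibitor, a lower number a stronger inhibitor. Compound 2 `C=C(C(=O)c1ccc(OC)cc1)C(OC(C)=O)C(CC)CC` gives 32900 nM in this assay, and compound 3 `C=C(C(=O)c1ccc(OC)cc1)C(OC(=O)c1ccccc1)C(CC)CC` gives 35200 nM. Among the compounds with values here, the only single-point step measured, a 1.1-fold higher number from compound 2 to compound 3 (0.03 log units; within the scatter), lies within the scatter. All three numbers sit within the scatter of one another, so compound 3 is neither separated from compound 2 nor from compound 1 by any step that can be read as a change.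

Compound 4 `C=C(C(=O)c1ccc(OC)cc1)C(OC(=O)c1ccccc1)c1ccccc1[N+](=O)[O-]` differs from compound 3 by 2-nitrophenyl in place of pentan-3-yl on a saturated chain carbon bound to a double-bonded chain carbon and an oxygen next to a carbonyl group. Within the data shown here, no measured step touches this position; the one step known, from compound 2 to compound 3, changes the ester and was flat. Among the measured compounds shown here, the series so far shows no change that moves the number beyond the scatter, so the expectation for compound 4 is a number close to that of compound 3, with a wide range because no precedent for this position exists. The expected step of a 1.0-fold lower number from compound 3 to compound 4 (0.00 log units; within the scatter) is thus small. Compound 4 is estimated at 35000 nM, between 12000 nM and 100000 nM.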

Compound 4, half-maximal inhibitory concentration: 45500 nM
Compound 4: the middle estimate sits 1.3-fold (0.11 log units) below what was measured; the measured number falls inside the stated range.
By their numbers in this assay, from the lowest: compounds 2, 3, 4 and 1 (each within the scatter of the next).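

At the saturated chain carbon bound to a double-bonded chain carbon and an oxygen next to a carbonyl group, the exchange of pentan-3-yl for 2-nitrophenyl gives a 1.3-fold higher number from compound 3 to compound 4 (0.11 log units; within the scatter) in this assay. Within the data shown here, this is the first reading at this position: a branched chain without a ring and an aromatic ring bearing a nitro group are not separated here, so this place, like the ester place, has yet to give a step beyond the scatter. No measurement bearing on why this step is flat is available.

Open, as far as these compounds go, is whether an amine or a carboxylic acid at this carbon, or a longer chain in place of pentan-3-yl, would separate from compound 3. Also open, from the compounds shown here alone, is what a free hydroxyl in place of the ester would give.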